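This account rests on a few compounds, and the source may have more. Where it says the series, first, only, none or still open, it means among the compounds named here.

In a functional assay on K562 cells (Homo sapiens) for inhibition, read by trypan blue exclusion, with a stated time of 72 h (a lower number here means a stronger inhibitor, a higher number a weaker inhibitor), compound 1 `Cn1c(=O)c(S(=O)(=O)c2ccc(C(=O)O)cc2)cc2cnc(Nc3ccc4[nH]ccc4c3)nc21` gives 5000 nM, compound 2 `Cn1c(=O)c(S(=O)(=O)c2ccc(F)cc2)cc2cnc(Nc3ccc4[nH]ccc4c3)nc21` gives 200 nM, and compound 3 `Cn1c(=O)c(S(=O)(=O)c2ccc(O)cc2)cc2cnc(Nc3ccc4[nH]ccc4c3)nc21` gives 100 nM. Compound 3 therefore cannot be told apart from compound 2, while compound 1 stands far from both.

Compound 4 `Cc1ccc(S(=O)(=O)c2cc3cnc(Nc4ccc5[nH]ccc5c4)nc3n(C)c2=O)cc1` has methyl in place of hydroxy on an aromatic carbon, para to a large group: methyl in place of hydroxy on an aromatic carbon.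

Among the compounds with values here, three measured steps bear on this change, all at the same place. Replacing fluoro with hydroxy gave a 2.0-fold lower number from compound 2 to compound 3 (0.30 log units; within the scatter), so this swap of one small group for another made no measurable difference. The large steps, a 25-fold lower number from compound 1 to compound 2 (1.40 log units; beyond the scatter) and a 50-fold lower number from compound 1 to compound 3 (1.70 log units; beyond the scatter), both start from carboxy, and methyl is a different kind of group. Within the data shown here, no measured compound carries methyl, so some uncertainty remains, but no step beyond the scatter is expected. The expected step is a 1.5-fold higher number from compound 3 to compound 4 (0.18 log units; within the scatter), with the number possibly rising slightly. The estimated value for compound 4 is 150 nM, with an expected range from 50 nM to 500 nM.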

Compound 4, half-maximal inhibitory concentration: 750 nM
Estimate against measurement, compound 4: 5.0-fold (0.70 log units) below, and the stated range ends below it.
By their numbers in this assay, from the lowest: compounds 3 and 2 (each within the scatter of the next); then compound 4; then compound 1.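

In this assay, this place on the ring turns out to be sensitive to a swap of one heavy atom for another: moving to methyl brings a 7.5-fold higher number from compound 3 to compound 4 (0.88 log units; beyond the scatter) and a 3.8-fold higher number from compound 2 to compound 4 (0.57 log units; beyond the scatter) even though fluoro and hydroxy could not be told apart. Carboxy remains the poorest of the groups shown, since replacing it with methyl still brings a 6.7-fold lower number from compound 1 to compound 4 (0.82 log units; beyond the scatter) and so places methyl in the middle of the series rather than beside either extreme. Nothing available here explains why methyl parts from hydroxy and fluoro.

As far as these compounds go, whether an amine, a methoxy group or a longer chain at this place would match hydroxy and fluoro, match methyl or fall elsewhere remains open. So does whether the step from hydroxy to methyl would keep its size on a different core.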